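A few compounds are considered here, and "the series" means these few. Any claim that something is new, unique, unknown or untested is made for them only; others in the source may bear on it.

Compound 3 `CCC1=C(O)c2c(oc(-c3ccc(C(F)(F)F)cc3)cc2=O)C(CC)(CC)C1=O` gives 35.7 uM in a functional assay on KB cells (Homo sapiens) for antiproliferative activity, read by sulforhodamine B assay, with a stated time of 3 days (on this read-out higher numbers stand for an effect only at larger amounts of compound and lower numbers for an effect already at smaller amounts), and stands highest of the two numbers shown. Compound 1 `CCC1=C(O)c2c(oc(-c3ccc(CC)cc3)cc2=O)C(CC)(CC)C1=O` gives 21.9 uM, and the step of a 1.6-fold higher number from compound 1 to compound 3 (0.21 log units; within the scatter) is within the scatter. Compound 2 `CCCc1ccc(-c2cc(=O)c3c(o2)C(CC)(CC)C(=O)C(CC)=C3O)cc1` gives only a limit of the assay, > 53 uM. The step of an at least 2.4-fold higher number from compound 1 to compound 2 (0.38 log units; beyond the scatter) lies beyond the scatter, whereas an at least 1.4-fold lower number from compound 2 to compound 3 (0.17 log units; that floor lies within the scatter) does not. Compound 4 `CCC1=C(O)c2c(oc(-c3ccc(SC)cc3)cc2=O)C(CC)(CC)C1=O` carries methylsulfanyl in place of trifluoromethyl on an aromatic carbon. The two earlier swaps of the group on this aromatic carbon, a 1.6-fold higher number from compound 1 to compound 3 (0.21 log units; within the scatter) and an at least 1.4-fold lower number from compound 2 to compound 3 (0.17 log units; that floor lies within the scatter), both stayed within the scatter, so no step beyond the scatter is expected here either. Compound 4 is therefore expected to give about 25 uM, within a range from 10 uM to 60 uM, which amounts to an estimated step of a 1.4-fold lower number from compound 3 to compound 4 (0.15 log units; within the scatter).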

Compound 4, concentration for half-maximal effect: > 52.1 uM
Compound 4: only a limit was reported; the forecaster's own chance of this, stated with the estimate: 15%; middle value at least 2.0-fold (0.31 log units) away from the limit.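

With methylsulfanyl on this aromatic carbon, the series gains a second group after propyl that separates from ethyl: an at least 2.3-fold higher number from compound 1 to compound 4 (0.37 log units; beyond the scatter). Against trifluoromethyl the result is less clear, as an at least 1.4-fold higher number from compound 3 to compound 4 (0.16 log units; that floor lies within the scatter) leaves methylsulfanyl and trifluoromethyl unseparated. Compound 2 and compound 4 each give only a limit, and the step between them cannot be read.

As far as these compounds go, how far the true values of compound 2 and compound 4 lie from their limits remains open. Also open, from the compounds shown here alone, is whether an amine or a carboxylic acid at this position would give a lower number than ethyl.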